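The compounds below may be only part of what the source reports. "The series", "measured", "known", "first", "only" and "open" are said of these compounds alone.

Compound 2 `COc1cc(-c2nn(-c3cccc(NC(=O)Nc4cccc(C(F)(F)F)c4)c3)cc2-c2ccncc2)ccc1Cl` gives 2160 nM in a functional assay on MDA-MB-468 cells (Homo sapiens) for inhibition, read by sulforhodamine B assay, with a stated time of 48 h (on this read-out lower numbers stand for stronger inhibition of growth and higher numbers for weaker inhibition of growth), the lower end of the two numbers recorded, though compound 1 `O=C(Nc1cccc(-n2cc(-c3ccncc3)c(-c3ccc(Cl)c(O)c3)n2)c1)Nc1ccc(Cl)c(Cl)c1`, with 4250 nM, lies within the scatter of it, so the two cannot be separated. Compound 3 `COc1cc(-c2nn(-c3cccc(NC(=O)c4ccccc4)c3)cc2-c2ccncc2)ccc1Cl` has not been measured in this assay. It differs from compound 2 in one place: phenyl in place of (3-(trifluoromethyl)phenyl)amino on a carbonyl carbon. Going by the values given here, no step between measured compounds is available to show how large such a change runs. The step from compound 2 to compound 3 is expected to be a rise beyond the scatter, a 3.0-fold higher number from compound 2 to compound 3 (0.48 log units; beyond the scatter). Compound 3 is therefore estimated at 6500 nM, within 2200 nM to 20000 nM.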

Compound 3, concentration for total growth inhibition: 3420 nM
Estimate against measurement, compound 3: 1.9-fold (0.28 log units) above; measured number inside the range.
By their numbers in this assay, from the lowest: compounds 2, 3 and 1 (each within the scatter of the next).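

In this assay phenyl in place of (3-(trifluoromethyl)phenyl)amino on a carbonyl carbon gives a 1.6-fold higher number from compound 2 to compound 3 (0.20 log units; within the scatter) and so cannot be told apart from no change. The leaving group carries the trifluoromethyl and a hydrogen-bond donor and phenyl carries neither, yet the read-out does not separate the two compounds. Nothing available explains this result.

The compounds shown leave open whether any group on this carbonyl carbon moves the number beyond the scatter. An unsubstituted phenylamino or a morpholine, for example, could still do so.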